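A few compounds are considered here, and "the series" means these few. Any claim that something is new, unique, unknown or untested is made for them only; others in the source may bear on it.

Measured so far in a functional assay on HepG2 cells (Homo sapiens) for cytotoxicity, read by MTT assay, with a stated time of 48 h; a lower number here means a stronger inhibitor, a higher number a weaker inhibitor:
Compound 1 `COc1ccc(/C=N/n2c(SCc3ccccc3Cl)nnc2-c2cc(OC)c(OC)c(OC)c2)c(OC)c1` — compound 1 gives > 200000 nM, a limit of the assay.
Compound 2 `COc1cc(-c2nnc3n2NC(CC(=O)c2ccc(C)cc2)(c2ccccc2)S3)cc(OC)c1OC` — compound 2 gives 580 nM.
Compound 3 `CCOC(=O)CC1(c2ccccc2)Nn2c(nnc2-c2cc(OC)c(OC)c(OC)c2)S1` — compound 3 gives > 200000 nM, a limit of the assay.

Going by the values given here, compound 2 is thus the only member of the series with an actual number in this assay; the other two results are limits and cannot be placed relative to each other or to compound 2 beyond that. Among the compounds with values here, the single measured step that changes one place, an at least 340-fold higher number from compound 2 to compound 3 (2.53 log units; beyond the scatter), exchanges the 4-methylphenyl on the carbonyl carbon for ethoxy; because of the limit of > 200000 nM in this assay, at which 2 of the 3 values shown sit, only a lower bound on its size is known.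

Compound 4 `COc1ccc(C2(CC(=O)c3ccc(C)cc3)Nn3c(nnc3-c3cc(OC)c(OC)c(OC)c3)S2)c(OC)c1` is the next compound to be measured. Its difference from compound 2 is 2,4-dimethoxyphenyl in place of phenyl on a saturated ring carbon. Within the data shown here, the 4-methylphenyl ketone side chain that separates compound 2 from compound 3 is kept unchanged, so the measured step does not bear on this change, and no measured pair varies the aryl group on the saturated ring carbon. Among the measured compounds shown here, there is therefore no ground in the data for a step as large as the one from compound 2 to compound 3; the expected step is a 1.2-fold higher number from compound 2 to compound 4 (0.08 log units; within the scatter), close to the scatter. Compound 4 is accordingly estimated at 700 nM, with a range from 150 nM to 4000 nM.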

Compound 4, half-maximal inhibitory concentration: 3170 nM
Estimate against measurement, compound 4: 4.5-fold (0.66 log units) below; measured number inside the range.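

Going by these compounds alone, the exchange of phenyl for 2,4-dimethoxyphenyl on the saturated ring carbon gives a 5.5-fold higher number from compound 2 to compound 4 (0.74 log units; beyond the scatter) in this assay, the only measured change at this position so far. The number therefore responds to the aryl group on this ring carbon as well as to the 4-methylphenyl ketone side chain, although this step is much smaller than the one on the carbonyl carbon, an at least 340-fold higher number from compound 2 to compound 3 (2.53 log units; beyond the scatter), whose size is known only as a lower bound. With the side chain kept, compound 4 still gives a real number and not a limit, and no measured property in the data accounts for the step from phenyl to 2,4-dimethoxyphenyl.

The two methoxy groups enter together, so the compounds shown do not tell whether one of them alone carries the step or both contribute. Going by these compounds, it also stays open how this ring carbon would respond to an aryl group of another kind, such as a pyridine ring, or to a plain methyl group in place of the aryl ring.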